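The source may report more compounds than this note shows. Statements on the series, on what has been measured and on what is new or still open speak of the compounds shown alone.

The series shares the core seen in compound 1 `O=C(Nc1ccc(Cl)c(-c2nnc3c(Cl)cccn23)c1)c1ccccc1Cl`, which in a functional assay on T47D cells (Homo sapiens) for antiproliferative activity, read by MTT assay, with a stated time of 72 h (on this read-out lower numbers stand for stronger inhibition and higher numbers for weaker inhibition), gives 83800 nM. Compound 2 `Cc1cc(Cl)ccc1C(=O)Nc1ccc(Cl)c(-c2nnc3c(Cl)cccn23)c1` differs from compound 1 by 4-chloro-2-methylphenyl in place of 2-chlorophenyl on a carbonyl carbon. In this assay compound 2 gives > 100000 nM, a limit of the assay rather than a number. Compound 3 `O=C(Nc1ccc(Cl)c(-c2nnc3c(Cl)cccn23)c1)c1ccc(C(F)(F)F)cc1Cl` carries trifluoromethyl in place of hydrogen on an aromatic carbon. In this assay compound 3 gives > 100000 nM, again a limit. The steps of an at least 1.1-fold higher number from compound 1 to compound 2 (0.07 log units; that floor lies within the scatter) and an at least 1.1-fold higher number from compound 1 to compound 3 (0.07 log units; that floor lies within the scatter) are both floors set by the limit of > 100000 nM in this assay, at which 2 of the 3 values shown sit. Among the compounds with values here, compound 2 stands at that limit, alongside compound 3, with compound 1 the only compound given as a number.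

Compound 4 `CS(=O)(=O)c1ccc(C(=O)Nc2ccc(Cl)c(-c3nnc4c(Cl)cccn34)c2)cc1` is the next member: 4-(methylsulfonyl)phenyl in place of 4-chloro-2-methylphenyl on a carbonyl carbon. Neither measured step bears directly on this change. Within the data shown here, both show only that aryl changes on the carbonyl carbon kept the values at or near the limit. No step beyond the scatter is therefore expected in this assay. A value near the limit is estimated, an at least 1.0-fold lower number from compound 2 to compound 4 (0.02 log units; that floor lies within the scatter). For compound 4 the expected value in this assay is 95000 nM, between 30000 nM and 300000 nM.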

Compound 4, half-maximal inhibitory concentration: > 100000 nM
Compound 4 gave a limit, no number; the forecaster's own chance of this, stated with the estimate: 55%; at least 1.0-fold (0.02 log units) between middle value and limit.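

Where 4-chloro-2-methylphenyl in compound 2 counts 0 hydrogen-bond acceptors, 4-(methylsulfonyl)phenyl counts 2, so the compounds shown now cover acceptors on this carbonyl carbon, and in this assay compound 4 still gives only a limit, not a number. The step of an at least 1.1-fold higher number from compound 1 to compound 4 (0.07 log units; that floor lies within the scatter) is no more than a floor, and the step between the two limit compounds cannot be read. Aryl groups with and without hydrogen-bond acceptors at this place therefore cannot be told apart in this assay, with compound 1 the only one given as a number: the limit of > 100000 nM in this assay, at which 3 of the 4 values shown sit.

From the compounds shown here alone, whether any group on this carbonyl carbon gives a value beyond the scatter of compound 1 remains open. Also open, going by these compounds, is how an aryl ring bearing an amine or a carboxylic acid, or a longer alkyl chain in place of the ring, would read in this assay.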